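The source may hold more compounds than are shown below. What is called first, only, known or untested is meant among the compounds shown, and "the series" means these compounds.

Three compounds built on one shared core have been run in a functional assay on the whole organism for inhibition, with Rattus norvegicus as the target, read by paw edema, with stated times of 1 h and 3 h, at a dose of 50 mg/kg by the oral route; a lower number here means less inhibition, a higher number more inhibition at the dose given (going by the name of the read-out). Compound 1 `C/C(=N\OCC(=O)O)c1ccccc1Cl` gives only a limit of the assay, < 20%. Compound 2 `C/C(=N\OCC(=O)O)c1cccc(Cl)c1` gives 20%. Compound 3 `C/C(=N\OCC(=O)O)c1ccc(C2CC2)cc1` also gives only a limit, < 20%, and its true value is not known. Where it stands is the limit of < 20% in this assay, at which 2 of the 3 values shown sit. Compound 4 `CC(=O)Nc1ccc(/C(C)=N/OCC(=O)O)cc1` has not yet been measured. The change from compound 3 to compound 4 is acetamido in place of cyclopropyl on an aromatic carbon. No measured pair differs in only one place, and the size of such a step is not shown by the data. The expectation for a number no lower from compound 3 to compound 4 (the limit leaves the size open) is a step no larger than the usual scatter, in either direction. Compound 4 is thus estimated at about 20%, between 10% and 35%, with a fair chance that only a limit is again reported.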

Compound 4, a percentage reported as inhibition, in the whole organism at one dose (the size of the read-out at that dose, not a potency): < 20%
Compound 4 was reported as a limit (the forecaster's own chance of this, stated with the estimate: 50%); the middle value lies on the limit itself.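

Compound 3 and compound 4 are both reported only as limits in this assay, and the step between them cannot be read. As far as these compounds go, whether acetamido or cyclopropyl gives more inhibition at this dose stays open.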